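Fluoro on the triazole aryl of a tert-butyl nitrone

A few compounds are considered here, and "the series" means these few. Any claim that something is new, unique, unknown or untested is made for them only; others in the source may bear on it.

Compound 3 `CC(C)(C)/[N+]([O-])=C/c1cn(-c2ccccc2)nn1` gives 17400 nM in a functional assay on A549 cells (Homo sapiens) for inhibition, read by MTT assay, with a stated time of 24 h; a higher number here means a weaker inhibitor, a lower number a stronger inhibitor. Compound 1 `[O-]/[N+](=C\c1cn(-c2ccc(F)cc2)nn1)c1ccccc1` gives 12500 nM in this assay, and the two numbers sit within the usual scatter of one another, so no order between them is claimed. Compound 2 `[O-]/[N+](=C\c1cn(-c2ccc(F)cc2)nn1)Cc1ccccc1` is reported in this assay only as a limit, > 100000 nM, as noted in the limit of > 100000 nM in this assay, at which 1 of the 3 values shown sits. Within the data shown here, the only single-point step measured is an at least 8.0-fold higher number from compound 1 to compound 2 (0.90 log units; beyond the scatter), which concerns the group on the double-bonded nitrogen and not the aryl ring on the shared core.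

Compound 4 `CC(C)(C)/[N+]([O-])=C/c1cn(-c2ccc(F)cc2)nn1` differs from compound 3 by fluoro in place of hydrogen on an aromatic carbon. Among the measured compounds shown here, no measured step isolates this change: compound 1 and compound 3 differ in two places at once, so their values cannot be split. The expectation for this assay is therefore a step of no size beyond the scatter, in either direction, and the expected step is a 1.2-fold lower number from compound 3 to compound 4 (0.06 log units; within the scatter). Compound 4 is estimated at 15000 nM, within 5000 nM to 45000 nM.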

Compound 4, half-maximal inhibitory concentration: 87000 nM
The estimate for compound 4 lay 5.8-fold (0.76 log units) below the measured number, outside the stated range (above it).
By their numbers in this assay, from the lowest: compounds 1 and 3 (each within the scatter of the next); then compound 4. At a limit, above all of these: compound 2.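

On the tert-butyl nitrone, placing fluoro on the six-membered aromatic ring, para to a large group, is not a silent change in this assay: it gives a 5.0-fold higher number from compound 3 to compound 4 (0.70 log units; beyond the scatter), the only measured read of this position. With fluoro held constant, exchanging the phenyl of the nitrone for tert-butyl gives a 7.0-fold higher number from compound 1 to compound 4 (0.84 log units; beyond the scatter), so the closeness of compound 1 and compound 3 does not mean that either of their two differences is silent. The value of compound 2 is a limit and not a number: the limit of > 100000 nM in this assay, at which 1 of the 4 values shown sits. The step that starts from this limit is only a floor, an at least 1.1-fold lower number from compound 2 to compound 4 (0.06 log units; that floor lies within the scatter), so it gives no size for that change.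

From the compounds shown here alone, whether the fluoro step holds with phenyl or benzyl on the double-bonded nitrogen stays open. Also open, going by these compounds, is whether it belongs to fluoro alone, or whether chloro, methoxy or an amine at the same place would give a similar step.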